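The compounds below may be only part of what the source reports. "The series", "measured", "known", "first", "only" and "open" are said of these compounds alone.

Measured compounds:
- compound 1, `CCCCNc1nc(N)nc(C)c1CCCN1CCCCC1`: 133 nM
- compound 2, `CCCCNc1nc(N)nc(C)c1CCc1ccccc1`: 1190 nM
- compound 3, `CCCCNc1nc(N)nc(C)c1CCCN1CCCCCC1`: 178 nM

In an assay on HEK293 cells for agonist activity at Toll-like receptor 8 (Homo sapiens), read by spectrophotometry (on this read-out higher numbers stand for an effect only at larger amounts of compound and lower numbers for an effect already at smaller amounts), compound 3 gives 178 nM, the second highest of the three numbers. Its nearest neighbour is compound 1, with 133 nM; the step of a 1.3-fold higher number from compound 1 to compound 3 (0.13 log units; within the scatter) lies within the scatter. The furthest is compound 2, with 1190 nM.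

Compound 4, `CCCCNc1nc(N)nc(C)c1CCCN(CC)CC`, has not been measured. It differs from compound 3 in one place: diethylamino in place of azepan-1-yl on a saturated chain carbon, three bonds along the chain from an aromatic carbon.

For the measured compounds named here, two measured steps bear on this change. The step of a 1.3-fold higher number from compound 1 to compound 3 (0.13 log units; within the scatter) shows that widening the saturated ring at this position moved the number only within the scatter. The step of an 8.9-fold higher number from compound 1 to compound 2 (0.95 log units; beyond the scatter) shows that replacing the basic ring with phenyl, on a shorter chain, raised the number well beyond the scatter. Compound 4 keeps a tertiary amine at the same position and only opens the ring, so the second step is less relevant than the first. Going by the values given here, no measured pair shows the ring-to-open-chain exchange itself. The expected step in this assay is therefore small, within or at the edge of the scatter, with a slight lean toward a higher number: a 1.2-fold higher number from compound 3 to compound 4 (0.09 log units; within the scatter) is the estimate.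

Compound 4 is expected to give about 220 nM in this assay, with a range from 90 nM to 500 nM.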

Compound 4, half-maximal effective concentration: 254 nM
Compound 4: middle estimate off by 1.2-fold (0.06 log units), on the low side, and the stated range covers the measured number.
By their numbers in this assay, from the lowest: compounds 1, 3 and 4 (each within the scatter of the next); then compound 2.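

In this assay the exchange of a ring for an open chain at this place, on a saturated chain carbon three bonds along the chain from an aromatic carbon, can now be read directly: azepan-1-yl to diethylamino gives a 1.4-fold higher number from compound 3 to compound 4 (0.15 log units; within the scatter) and piperidin-1-yl to diethylamino gives a 1.9-fold higher number from compound 1 to compound 4 (0.28 log units; within the scatter) with both steps inside the scatter. The ring on the nitrogen is therefore not required for this level of the read-out, and piperidin-1-yl, azepan-1-yl and diethylamino cannot be told apart here, whereas the phenyl compound stands apart, with a 4.7-fold lower number from compound 2 to compound 4 (0.67 log units; beyond the scatter) as a step beyond the scatter that shows the gap first seen with compound 1 also holds for an open-chain amine. Nothing available explains why these three amines read alike.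

The compounds shown leave open whether a smaller dimethylamino group, a secondary amine such as ethylamino, or a morpholin-4-yl ring with its added oxygen would fit the same picture. They also leave open how much of the step from the amines to the phenyl compound belongs to the group itself and how much to the shorter chain that carries it, and what a longer chain to the amine would do.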